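Benzoxazolyl for phenyl on the amine nitrogen

The source may report more compounds than this note shows. Statements on the series, on what has been measured and on what is new or still open speak of the compounds shown alone.

Measured in a functional assay (aorta) with Rattus norvegicus as the target; a lower number here means a stronger inhibitor, a higher number a weaker inhibitor:
- compound 1 `CCOC(=O)CN(c1ccccc1)[C@H]1c2cc(C#N)ccc2OC(C)(C)[C@@H]1O`: > 30000 nM (a limit)
- compound 2 `CC1(C)Oc2ccc(C#N)cc2[C@H](N(CC(=O)O)c2ccccc2)[C@H]1O`: > 100000 nM (a limit)
- compound 3 `CCCCOC(=O)CN(c1ccccc1)[C@H]1c2cc(C#N)ccc2OC(C)(C)[C@@H]1O`: 27000 nM

The position of compound 1 is known only as a limit, > 30000 nM, and not as a number. Compound 4 `CCOC(=O)CN(c1nc2ccccc2o1)[C@H]1c2cc(C#N)ccc2OC(C)(C)[C@@H]1O` keeps the core of compound 1 and its ethyl ester, with 1,3-benzoxazol-2-yl in place of phenyl on an amine nitrogen.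

For the measured compounds named here, no measured step touches that group, so the evidence is indirect. The ester changes give an at least 1.1-fold lower number from compound 1 to compound 3 (0.04 log units; that floor lies within the scatter), then an at least 3.7-fold lower number from compound 2 to compound 3 (0.56 log units; beyond the scatter), and finally a step that the two limits leave unreadable from compound 1 to compound 2. Even after these changes, compound 3 gives only 27000 nM, the one true number in the series. On that basis, compound 4 is expected to stay in the same high range in this assay, with no clear gain. The expected change is a step that the limit leaves unreadable from compound 1 to compound 4. For compound 4 the estimate is 35000 nM, with an expected range of 9000 nM to 100000 nM.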

Compound 4, half-maximal inhibitory concentration: > 30000 nM
Compound 4: a limit, no number (the forecaster's own chance of this, stated with the estimate: 55%); the middle value is on the limit's open side.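

In this assay compound 4 gives > 30000 nM, which is a limit. Compound 1 also stands at a limit, so no step can be read between compound 1 and compound 4. The compounds shown leave open whether 1,3-benzoxazol-2-yl in place of phenyl on the amine nitrogen changes the number in either direction.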